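Swapping chloro for fluoro on a weakly active core

The source may report more compounds than this note shows. Statements on the series, on what has been measured and on what is new or still open speak of the compounds shown alone.

Compound 1 `CCC1(CCCCN2CC=C(c3ccc(Cl)cc3)CC2)C(=O)Nc2ccccc21` was tested in a functional assay on the whole organism (strain Wistar) with Rattus norvegicus as the target, with a stated time of 5 min; a lower number here means that less compound is needed, a higher number that more compound is needed for the effect. In this assay compound 1 gives only a limit, > 20 mg/kg, not a number. Two related compounds carry a different ring on the chain. Compound 2 `CCC1(CCCCN2CCN(c3cccc(Cl)c3)CC2)C(=O)Nc2cc(F)ccc21` likewise reaches only a limit in this assay, > 20 mg/kg. Among the measured compounds shown here, compound 3 `CCC1(CCCCN2CCN(c3cccc(Cl)c3)CC2)C(=O)Nc2cc(F)c(Cl)cc21` is the one compound with a number, giving 20 mg/kg in this assay. For the measured compounds named here, the single measured step, a number no higher from compound 2 to compound 3 (the limit leaves the size open), is a change elsewhere on the core and does not touch the group altered here. Compound 4 `CCC1(CCCCN2CC=C(c3ccc(F)cc3)CC2)C(=O)Nc2ccccc21` has not yet been measured. It differs from compound 1 in one place: fluoro in place of chloro on an aromatic carbon. Going by the values given here, no measured step bears directly on this change, and the limit of > 20 mg/kg in this assay, at which 2 of the 3 values shown sit, is the only guide, so the expected step, a step that the limit leaves unreadable from compound 1 to compound 4, is small with its direction open. Compound 4 is therefore estimated at 30 mg/kg, with a range from 10 mg/kg to 100 mg/kg, and it is expected most likely to be reported again as a limit.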

Compound 4, minimum effective dose: 20 mg/kg
For compound 4 the middle estimate is 1.5-fold (0.18 log units) above the measured one, and the stated range covers the measured number.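

In this assay compound 4 gives 20 mg/kg, a true number where the 4-chlorophenyl compound offers none. Compound 1 gives only a limit, > 20 mg/kg. Fluoro in place of chloro at this spot therefore gives a number no higher from compound 1 to compound 4 (the limit leaves the size open), but the size of that step cannot be read, and the picture still leans heavily on one value: the limit of > 20 mg/kg in this assay, at which 2 of the 4 values shown sit.

From the compounds shown here alone, it remains open how far apart the 4-fluorophenyl and 4-chlorophenyl compounds really lie, and whether fluoro differs from chloro here at all. Going by these compounds, it is also open what plain hydrogen, a methoxy group, a trifluoromethyl group or an amine would give at this same place on the ring, and whether any of them would need less compound than compound 4 for the effect.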